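Halogen swap at the para position: chloro for fluoro

A few compounds are considered here, and "the series" means these few. Any claim that something is new, unique, unknown or untested is made for them only; others in the source may bear on it.

Measured compounds:
- compound 1, `O=C(CSc1nnnn1-c1ccccc1)N/N=c1/scc(-c2ccc(Br)cc2)n1-c1ccccc1`: 21 ug/mL
- compound 2, `COc1ccc(-c2cs/c(=N/NC(=O)CSc3nnnn3-c3ccccc3)n2-c2ccccc2)cc1`: "not determined" (no result reported)
- compound 3, `O=C(CSc1nnnn1-c1ccccc1)N/N=c1/scc(-c2ccc(F)cc2)n1-c1ccccc1`: 24.3 ug/mL

Three compounds share one core, differing only in the group on the phenyl ring. In a functional assay on C6 cells (Rattus norvegicus) for cytotoxicity, read by MTT assay, with a stated time of 24 h (on this read-out higher numbers stand for weaker inhibition and lower numbers for stronger inhibition), compound 1 gives 21 ug/mL and compound 3 gives 24.3 ug/mL; for compound 2 the entry reads "not determined" (no result reported). For the measured compounds named here, the only single-point step measured is a 1.2-fold higher number from compound 1 to compound 3 (0.06 log units; within the scatter), so compound 3 and compound 1 cannot be placed in any order on this read-out. Among the two numbers reported in this assay, compound 3 carries the higher one, but the gap to compound 1 is well inside the scatter.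

Compound 4, `O=C(CSc1nnnn1-c1ccccc1)N/N=c1/scc(-c2ccc(Cl)cc2)n1-c1ccccc1`, differs from compound 3 as follows: chloro in place of fluoro on an aromatic carbon. Going by the values given here, the only step that bears on it is the bromo-to-fluoro exchange at the same place, which gave a 1.2-fold higher number from compound 1 to compound 3 (0.06 log units; within the scatter). A chloro group at that position sits between those two halogens in the series already measured, and both halogens gave numbers within the scatter of each other. Compound 4 is therefore expected to land close to compound 3 in this assay, with an estimated step of a 1.1-fold lower number from compound 3 to compound 4 (0.04 log units; within the scatter). The estimate for compound 4 is 22 ug/mL, with a range from 12 ug/mL to 40 ug/mL.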

Compound 4, half-maximal inhibitory concentration: > 200 ug/mL
Compound 4: only a limit was reported; the forecaster's own chance of this, stated with the estimate: 5%; middle value at least 9.0-fold (0.95 log units) away from the limit.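

In this assay the result for compound 4 is a limit and not a number: compound 4 gives > 200 ug/mL. Until now this position on the phenyl ring had seemed indifferent to the choice of halogen, with a 1.2-fold higher number from compound 1 to compound 3 (0.06 log units; within the scatter), but the 4-chlorophenyl group parts clearly from both others, with an at least 8.2-fold higher number from compound 3 to compound 4 (0.91 log units; beyond the scatter) and an at least 9.5-fold higher number from compound 1 to compound 4 (0.97 log units; beyond the scatter), so among these three compounds the read-out does not run in step with the order of the halogens in the periodic table. On these data alone, the true size of both new steps stays open on the upper side, because the result for compound 4 is bounded in one direction only: the limit of > 200 ug/mL in this assay, at which 1 of the 4 values shown sits.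

The compounds shown leave open whether this sharp step belongs to the chloro group alone, or whether other groups on the same aromatic carbon, such as iodo, an amine or a carboxylic acid, would also part from the values of compound 1 and compound 3. They also leave open how far past its limit compound 4 lies and what lies behind the step.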